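This account rests on a few compounds, and the source may have more. Where it says the series, first, only, none or still open, it means among the compounds named here.

Measured so far:
Compound 1, `COc1cccc(/C=C/C(=O)Nc2cc(OC)c(OC)c(OC)c2)c1`, in a functional assay on COLO 205 cells (Homo sapiens) for cytotoxicity, read by MTT assay, with a stated time of 72 h (on this read-out lower numbers stand for stronger inhibition and higher numbers for weaker inhibition), gives 4200 nM.
Compound 2, `COc1ccc(C(=O)c2cc(OC)c(OC)c(OC)c2)cc1NC(=O)/C=C/c1cc(OC)c(OC)c(OC)c1`, in this assay gives 5200 nM.

Going by the values given here, these two numbers sit within the usual scatter of each other, so they show no difference in cytotoxicity between compound 1 and compound 2; compound 2 simply carries the higher of the two readings, with compound 1 as its only neighbour.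

Compound 3, `COc1ccc(C(=O)c2cc(OC)c(OC)c(OC)c2)cc1NC(=O)/C=C/c1ccc(C(F)(F)F)cc1`, keeps the core of compound 2 and changes one part: 4-(trifluoromethyl)phenyl in place of 3,4,5-trimethoxyphenyl on a double-bonded chain carbon bound to a double-bonded chain carbon. Among the compounds with values here, no step between two measured compounds with this kind of exchange exists, so there is nothing to lean on beyond the two values shown. The aryl group on the amide-bearing double bond already differs between compound 1 and compound 2 without a change beyond the scatter, which suggests the step from compound 2 to compound 3 is expected to stay small in this assay, as a 1.3-fold higher number from compound 2 to compound 3 (0.10 log units; within the scatter). Compound 3 is therefore estimated at 6500 nM, within a range from 2000 nM to 20000 nM.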

Compound 3, half-maximal inhibitory concentration: 2600 nM
Estimate against measurement, compound 3: 2.5-fold (0.40 log units) above; low and high end bracket the measured number.
By their numbers in this assay, from the lowest: compounds 3, 1 and 2 (each within the scatter of the next).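

In this assay, the exchange at this place, on a double-bonded chain carbon bound to a double-bonded chain carbon, gives a 2.0-fold lower number from compound 2 to compound 3 (0.30 log units; within the scatter). Going by these compounds alone, this is the first direct reading of this position with everything else held the same, and it shows that 3,4,5-trimethoxyphenyl, with 3 hydrogen-bond acceptors, and 4-(trifluoromethyl)phenyl, with 0, cannot be told apart by this read-out. Nothing measured here offers an explanation for that result.

Within the data shown here, with only this one exchange at this place, it remains open whether any group there can move the reading beyond the scatter. An aryl group carrying an amine or a carboxylic acid, or a longer chain in place of the double-bonded one, would test how far this tolerance extends.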